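Ester and demethylated aryl variant in the mGlu3 PAM series

A few compounds are considered here, and "the series" means these few. Any claim that something is new, unique, unknown or untested is made for them only; others in the source may bear on it.

Measured so far:
compound 1, `Cc1cc(C(=O)O)ccc1OCCCCOc1ccc(C(=O)CC(C)C)c(O)c1C`: 42.1%
compound 2, `CCCC(=O)c1ccc(OCCCCOc2ccc(C(=O)O)cc2C)c(C)c1O`: 40.5%

Both compounds were tested in an assay on HEK293 cells for positive allosteric modulation of metabotropic glutamate receptor 3 (Rattus norvegicus), read by thallium flux, with a stated time of 2.5 min; on this read-out higher numbers stand for larger maximal responses and lower numbers for smaller maximal responses. Compound 1 gives 42.1%, the higher of the two numbers, and compound 2 gives 40.5%, which is within the scatter of compound 1. Within the data shown here, the only step with both ends measured is a number 1.6 percentage points lower from compound 1 to compound 2 (within the scatter), a change on the saturated side chain that leaves the maximal response unchanged beyond the scatter.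

Compound 3, `COC(=O)c1ccc(OCCCCOc2ccc(C(=O)CC(C)C)c(O)c2C)cc1`, is not yet measured. It differs from compound 1 by 4-(methoxycarbonyl)phenyl in place of 4-carboxy-2-methylphenyl on an oxygen on a saturated carbon. Among the measured compounds shown here, no measured step touches this part of the molecule: the one known step concerns the alkyl chain, not the aryl ether end, so it offers no guidance on direction or size. For the measured compounds named here, with no precedent, the working expectation is a number near that of compound 1 with a broad range, expressed as a number 6.1 percentage points lower from compound 1 to compound 3 (within the scatter). Compound 3 is therefore estimated at 36% in this assay, with a range from 10% to 60%.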

Compound 3, largest response reached (reported as percent of maximum), in percent of the reference or control that the assay uses: 22.7%
The estimate for compound 3 lay 13.3 percentage points above the measured number; the range from low to high includes it.
By their numbers in this assay, from the lowest: compound 3; then compounds 2 and 1 (each within the scatter of the next).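

In this assay, 4-(methoxycarbonyl)phenyl in place of 4-carboxy-2-methylphenyl on an oxygen on a saturated carbon gives a number 19.4 percentage points lower from compound 1 to compound 3 (beyond the scatter), whereas the change on the saturated side chain gave a number 1.6 percentage points lower from compound 1 to compound 2 (within the scatter). The maximal response of the series therefore responds to the aryl group on this oxygen, and this is the first step shown to go beyond the scatter; the count under the change goes from 1 hydrogen-bond donor and 1 hydrogen-bond acceptor to 0 donors and 2 acceptors, though that count is only a description of the swap. Nothing available gives a reason for this step.

The swap changes two features at once, the free carboxylic acid becoming a methyl ester and the methyl group on the aryl ring going, so the compounds shown do not separate their contributions. Also open, going by these compounds, are 4-carboxyphenyl, which would carry the acid without that methyl group, and the methyl ester with the methyl group retained, as well as whether a primary amide on this ring would hold the response of compound 1.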